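A few compounds are considered here, and "the series" means these few. Any claim that something is new, unique, unknown or untested is made for them only; others in the source may bear on it.

Of the compounds shown here, three sharing one core have been measured in a functional assay on L6 cells (Rattus norvegicus) for cytotoxicity; on this read-out higher numbers stand for weaker inhibition and lower numbers for stronger inhibition. Compound 1 `Nc1nc(N)nc(N/N=C/c2ccc([N+](=O)[O-])o2)n1` gives 183000 nM, and compound 3 `CN(C)c1nc(N)nc(N/N=C/c2ccc([N+](=O)[O-])o2)n1` gives 110000 nM, which lies within the scatter of compound 1. Compound 2 `CNc1nc(NC)nc(N/N=C/c2ccc([N+](=O)[O-])o2)n1` gives 44100 nM, a clearly lower number than either of the others, so compound 3 stands level with compound 1 and beyond the scatter above compound 2.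

The next compound is compound 4 `CNc1nc(N)nc(N/N=C/c2ccc([N+](=O)[O-])o2)n1`, which differs from compound 3 by hydrogen in place of methyl on a nitrogen on an aromatic ring, so that dimethylamino becomes methylamino. Going by the values given here, the one measured step that changes a single place, a 1.7-fold lower number from compound 1 to compound 3 (0.22 log units; within the scatter), touches the same kind of group and stays within the scatter. Among the compounds with values here, compound 2, which also carries methylamino and gives 44100 nM, hints at a somewhat lower number, yet no single measured step isolates that group. A small move downward is therefore possible, but nothing beyond the scatter is anticipated.

In this assay the estimated change is a 1.2-fold lower number from compound 3 to compound 4 (0.09 log units; within the scatter), which is expected to stay within the scatter. For compound 4 the expected value is 90000 nM, with an estimated range of 50000 nM to 160000 nM.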

Compound 4, half-maximal inhibitory concentration: 48900 nM
Estimate against measurement, compound 4: 1.8-fold (0.26 log units) above; measured number outside the range, below it.
By their numbers in this assay, from the lowest: compounds 2 and 4 (each within the scatter of the next); then compounds 3 and 1 (each within the scatter of the next).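

In this assay the change from dimethylamino to methylamino moves the number beyond the scatter (a 2.2-fold lower number from compound 3 to compound 4 (0.35 log units; beyond the scatter)), and so does methyl in place of hydrogen when it starts from amino (a 3.7-fold lower number from compound 1 to compound 4 (0.57 log units; beyond the scatter)). Read with the earlier step from amino to dimethylamino (a 1.7-fold lower number from compound 1 to compound 3 (0.22 log units; within the scatter)), the response at this nitrogen is not stepwise: the first methyl lowers the number, while the second on the same nitrogen leaves compound 3 within the scatter of compound 1. Hydrogen in place of methyl on the other exocyclic nitrogen shows no readable change (a 1.1-fold higher number from compound 2 to compound 4 (0.04 log units; within the scatter)), so in these compounds a second methyl on that nitrogen leaves the number level, unlike a second methyl on the nitrogen that becomes dimethylamino.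

Going by these compounds, whether ethylamino, a longer chain or a cyclic amine such as pyrrolidine at this place would read like methylamino or like dimethylamino stays open. Nothing in the material shown explains why one methyl and two methyls on the same nitrogen differ in this way.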